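Swapping one ring of a symmetric disulfide for another

The source may report more compounds than this note shows. Statements on the series, on what has been measured and on what is new or still open speak of the compounds shown alone.

The series is built on disulfide-linked nucleoside pairs tested in an assay on isolated protein for inhibition of NAD kinase (Homo sapiens), read by HPLC; a lower number here means a stronger inhibitor, a higher number a weaker inhibitor. Compound 1 `Nc1ncnc2c1nc(Br)n2[C@@H]1O[C@H](CSSC[C@H]2O[C@@H](n3c(Br)nc4c(N)ncnc43)[C@H](O)[C@@H]2O)[C@@H](O)[C@H]1O` gives 6000 nM, and compound 2 `Nc1ncnc2c1ncn2[C@@H]1O[C@H](CSSC[C@H]2O[C@@H](n3c(Br)nc4c(N)ncnc43)[C@H](O)[C@@H]2O)[C@@H](O)[C@H]1O` gives 6000 nM; the step of no change at the digits printed from compound 1 to compound 2 (within the scatter) shows that removing the bromo leaves the outcome unchanged. Compound 3 `NC(=O)c1csc([C@@H]2O[C@H](CSSC[C@H]3O[C@@H](c4nc(C(N)=O)cs4)[C@H](O)[C@@H]3O)[C@@H](O)[C@H]2O)n1`, which carries the 4-carbamoyl-1,3-thiazol-2-yl group at each end of the disulfide, is recorded in this assay as "not active" (no number reported), so no number exists for it. Compound 4 `NC(=O)c1csc([C@@H]2O[C@H](CSSC[C@H]3O[C@@H](n4cnc5c(N)ncnc54)[C@H](O)[C@@H]3O)[C@@H](O)[C@H]2O)n1` differs from compound 3 in one place: a group of 10 heavy atoms (5 carbon, 5 nitrogen; one five-membered aromatic ring with 2 hetero atoms, one six-membered aromatic ring with 2 hetero atoms) in place of a group of 8 heavy atoms (4 carbon, 2 nitrogen, 1 oxygen, 1 sulfur; one five-membered aromatic ring with 2 hetero atoms), on a saturated ring carbon. Within the data shown here, no measured step covers exactly this change, but compounds 1 and 2, in which each end of the disulfide carries the group that enters in compound 4, reach the low micromolar range, whereas compound 3 with neither does not. Compound 4, which carries one group of each kind, is therefore expected to lie between these outcomes, weaker than compound 1 and compound 2 yet possibly measurable. Compound 4 is estimated at 15000 nM, with a range from 4000 nM to 60000 nM.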

Compound 4, half-maximal inhibitory concentration: 110000 nM
Compound 4: the middle estimate sits 7.3-fold (0.87 log units) below what was measured; measured number outside the range, above it.
By their numbers in this assay, from the lowest: compounds 1 and 2 (each within the scatter of the next); then compound 4.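

In this assay, the step of an 18-fold higher number from compound 2 to compound 4 (1.26 log units; beyond the scatter) shows that the group on this saturated ring carbon, next to the ring oxygen, matters: placing the 4-carbamoyl-1,3-thiazol-2-yl group there costs far more than the bromo change did in the step of no change at the digits printed from compound 1 to compound 2 (within the scatter). Compound 4 also has a number, whereas compound 3 is recorded as "not active", so one end bearing the two-ring group is enough for a measurable value, although the change from compound 3 to compound 4 cannot be read as a step. Nothing available here explains the size of this loss.

The compounds shown leave open whether a bromo on the remaining two-ring group of compound 4 would change its value, as it did not between compound 1 and compound 2. They also leave open how a carboxylic acid in place of the carbamoyl group would behave at this position.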